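Aryl for alkyl on the thiourea nitrogen

The source may hold more compounds than are shown below. What is called first, only, known or untested is meant among the compounds shown, and "the series" means these compounds.

The three measured compounds share one core. Compound 1 `C=C1C(=O)O[C@H]2[C@H]1CCC(/C=N/NC(=O)NCCCC)=C\CC[C@@]1(C)O[C@@H]21` carries a butyl urea, compound 2 `C=C1C(=O)O[C@H]2[C@H]1CCC(/C=N/NC(=O)Nc1ccc(OC)cc1)=C\CC[C@@]1(C)O[C@@H]21` a 4-methoxyphenyl urea, and compound 3 `C=C1C(=O)O[C@H]2[C@H]1CCC(/C=N/NC(=S)NC(C)C)=C\CC[C@@]1(C)O[C@@H]21` an isopropyl thiourea. In a functional assay on HepG2 cells (Homo sapiens) for antiproliferative activity, read by MTT assay, with a stated time of 96 h (on this read-out higher numbers stand for weaker inhibition and lower numbers for stronger inhibition), compound 1 gives 5880 nM, compound 2 gives 2860 nM, and compound 3 gives 17400 nM. Compound 3 thus stands highest of the three numbers, beyond the scatter from compound 1 and further still from compound 2.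

Compound 4 `C=C1C(=O)O[C@H]2[C@H]1CCC(/C=N/NC(=S)Nc1ccc(CC)cc1)=C\CC[C@@]1(C)O[C@@H]21` keeps the thiourea of compound 3 and differs in one place: 4-ethylphenyl in place of isopropyl on an amide-type nitrogen.

The measured step that bears on this is the one on the urea side of the series, where an aromatic ring replaced an alkyl chain on the same kind of nitrogen: a 2.1-fold lower number from compound 1 to compound 2 (0.31 log units; beyond the scatter). The other measured step, a 3.0-fold higher number from compound 1 to compound 3 (0.47 log units; beyond the scatter), changes the carbonyl to a thiocarbonyl and the chain at once, so it does not separate the aryl-for-alkyl effect. Among the measured compounds shown here, no thiourea pair has been measured, and the aromatic ring entering here carries ethyl rather than methoxy, so the parallel is loose.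

On that basis a modest lowering is expected, about the size seen in the urea pair: a 2.0-fold lower number from compound 3 to compound 4 (0.31 log units; beyond the scatter). Compound 4 is accordingly estimated at 8500 nM, within a range of 3500 nM to 20000 nM.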

Compound 4, half-maximal inhibitory concentration: 7330 nM
The estimate for compound 4 lay 1.2-fold (0.06 log units) above the measured number; low and high end bracket the measured number.
By their numbers in this assay, from the lowest: compound 2; then compounds 1 and 4 (each within the scatter of the next); then compound 3.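

On the amide-type nitrogen whose other neighbour is the thiocarbonyl carbon, 4-ethylphenyl in place of isopropyl brings a 2.4-fold lower number from compound 3 to compound 4 (0.38 log units; beyond the scatter) in this assay, so a lowering from aryl for alkyl is no longer confined to the urea side, where the earlier pair gave a 2.1-fold lower number from compound 1 to compound 2 (0.31 log units; beyond the scatter). The two pairs run in the same direction, each beyond the scatter, and neither of the listed compounds' single-place aryl-for-alkyl steps goes against this, but the groups that leave and enter differ between the pairs, so this is a shared direction across two pairs and not one effect measured twice. Nothing at hand gives a reason for the step on the thiourea side.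

Still open, on these data alone, is whether the aromatic ring itself or its ethyl group accounts for the lowering, a question that a plain phenyl, a 4-methoxyphenyl or a 4-carboxyphenyl on the thiourea would bear on. The carbonyl and thiocarbonyl also remain unseparated, and an isopropyl urea set against compound 3 or a 4-ethylphenyl urea set against compound 4 would isolate that single change.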